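This account rests on a few compounds, and the source may have more. Where it says the series, first, only, none or still open, it means among the compounds named here.

For the measured compounds named here, compound 3 `COc1ccc(CN2C(=O)C(=O)c3cc(-c4ccc(OC)cc4)ccc32)cc1` stands lowest of the three numbers measured so far: in a functional assay on HepG2 cells (Homo sapiens) for antiproliferative activity, read by MTT assay, with a stated time of 48 h (a higher number here means a weaker inhibitor, a lower number a stronger inhibitor), compound 3 gives 50 nM, while compound 2 `COc1ccc(-c2ccc3c(c2)C(=O)C(=O)N3Cc2cccc(Cl)c2)cc1` gives 320 nM and compound 1 `CCN1C(=O)C(=O)c2cc(-c3ccc(OC)cc3)ccc21` gives 4470 nM. Compound 4 `COc1ccc(CN2C(=O)C(=O)c3cc(-c4ccc(OC)c(OC)c4)ccc32)cc1` differs from compound 3 by methoxy in place of hydrogen on an aromatic carbon. Every measured step, a 14-fold lower number from compound 1 to compound 2 (1.15 log units; beyond the scatter), an 89-fold lower number from compound 1 to compound 3 (1.95 log units; beyond the scatter) and a 6.4-fold lower number from compound 2 to compound 3 (0.81 log units; beyond the scatter), alters the group on the saturated chain carbon bound to the amide-type nitrogen, not the aromatic ring changed here, so none of them bears directly on this step. With no comparable change measured, the expected step is a 1.2-fold higher number from compound 3 to compound 4 (0.08 log units; within the scatter), inside the usual scatter. Compound 4 is estimated at 60 nM, with a range from 20 nM to 200 nM.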

Compound 4, half-maximal inhibitory concentration: > 10000 nM
Compound 4: a limit, no number; the forecaster's own chance of this, stated with the estimate: 2%; middle value at least 160-fold (2.22 log units) from the limit.
By their numbers in this assay, from the lowest: compound 3; then compound 2; then compound 1. At a limit, above all of these: compound 4.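

For the compounds shown here, on this aromatic ring, which the earlier compounds left unchanged, a single methoxy in place of hydrogen, ortho to a methoxy group and meta to a large group, gives an at least 200-fold higher number from compound 3 to compound 4 (2.30 log units; beyond the scatter). In this assay compound 4 stands at a limit, not a number: the limit of > 10000 nM in this assay, at which 1 of the 4 values shown sits. The activity of compound 3 therefore does not survive this change from 4-methoxyphenyl to 3,4-dimethoxyphenyl, although the shared core and the 4-methoxyphenyl group on the chain carbon are kept.

The compounds shown leave open whether a fluorine, a hydroxy or a methyl on this carbon would have the same result as methoxy. They also leave open how much activity compound 4 retains beyond its limit.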